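Adding a Dimethylamino Group to Compound 2

The source may hold more compounds than are shown below. What is called first, only, known or untested is meant among the compounds shown, and "the series" means these compounds.

Compound 2 `CC(C)c1ccccc1-c1nccc(NCc2ccc(-c3cccnc3)cc2)n1` is the starting point. In an assay on a protein complex for inhibition of ubiquitin carboxyl-terminal hydrolase 1/WD repeat-containing protein 48 (Homo sapiens), read by fluorescence (on this read-out higher numbers stand for weaker inhibition and lower numbers for stronger inhibition), compound 2 gives 150 nM, the lowest number among the three measured. Compound 3 `Cc1cc(NCc2ccc(-c3cccnc3)cc2)nc(-c2ccccc2C(C)C)n1` gives 210 nM in this assay, and the step of a 1.4-fold higher number from compound 2 to compound 3 (0.15 log units; within the scatter) lies within the scatter, so these two cannot be ranked. Compound 1 `O=[N+]([O-])c1ccccc1-c1nc(NCc2ccc(-c3cccnc3)cc2)c2ccccc2n1` gives 7800 nM, far beyond the scatter from compound 2. Compound 4 `CC(C)c1ccccc1-c1ncc(N(C)C)c(NCc2ccc(-c3cccnc3)cc2)n1` differs from compound 2 by dimethylamino in place of hydrogen on an aromatic carbon. For the measured compounds named here, the only single-change step measured, a 1.4-fold higher number from compound 2 to compound 3 (0.15 log units; within the scatter), concerns a methyl group replacing hydrogen and stayed within the scatter; no measured step tests an added dimethylamino group. The step of a 1.3-fold higher number from compound 2 to compound 4 (0.12 log units; within the scatter) is therefore expected to stay within the scatter. The estimate for compound 4 is 200 nM, in a range from 60 nM to 700 nM.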

Compound 4, half-maximal inhibitory concentration: 190 nM
For compound 4 the middle estimate is 1.1-fold (0.02 log units) above the measured one, and the stated range covers the measured number.
By their numbers in this assay, from the lowest: compounds 2, 4 and 3 (each within the scatter of the next); then compound 1.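

In this assay, placing dimethylamino on this aromatic carbon, two atoms from the ring nitrogen, gives a 1.3-fold higher number from compound 2 to compound 4 (0.10 log units; within the scatter). For the compounds shown here, no earlier step tested this position, and this one shows that it can carry dimethylamino with no change that can be told from the usual scatter. Nothing available explains this outcome.

Going by these compounds, it remains open whether methylamino, morpholine or a carboxylic acid on the same carbon would also stay within the scatter. A single substituent also cannot show how far this tolerance extends to other groups.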